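A few compounds are considered here, and "the series" means these few. Any claim that something is new, unique, unknown or untested is made for them only; others in the source may bear on it.

Compound 1 `CCS(=O)(=O)Nc1ccc(NC(=O)c2ccc(C#N)cc2)cc1F` carries an ethylsulfonyl group on its sulfonamide nitrogen, and in an ADME assay on HEK293 cells (Homo sapiens) for cytotoxicity, read by MTT assay, with a stated time of 48 h (a lower number here means a stronger inhibitor, a higher number a weaker inhibitor), compound 1 gives 26400 nM. Compound 3 `N#Cc1ccc(C(=O)Nc2ccc(NS(=O)(=O)C(F)(F)F)c(F)c2)cc1` differs from it by trifluoromethyl in place of ethyl on a sulfonyl sulfur. For compound 3, this assay reports only a limit, > 250000 nM. The resulting step, an at least 9.4-fold higher number from compound 1 to compound 3 (0.97 log units; beyond the scatter), is bounded by the limit of > 250000 nM in this assay, at which 1 of the 3 values shown sits, so its true size is not known.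

Compound 2 `CCS(=O)(=O)Nc1ccc(NC(=O)c2cccc(C(F)(F)F)c2)cc1F` has a different core; how the cores of compound 1 and compound 2 differ is not broken down here. In this assay compound 2 gives 94800 nM.

Compound 4 `O=C(Nc1ccc(NS(=O)(=O)C(F)(F)F)c(F)c1)c1cccc(C(F)(F)F)c1` is not yet measured. It differs from compound 2 by trifluoromethyl in place of ethyl on a sulfonyl sulfur, the same change at the same place as before. Given the earlier step of an at least 9.4-fold higher number from compound 1 to compound 3 (0.97 log units; beyond the scatter), compound 4 is expected to show a step of a 2.6-fold higher number from compound 2 to compound 4 (0.42 log units; beyond the scatter). Compound 4 is therefore estimated at 250000 nM, and its value may again come back only as a limit.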

Compound 4, half-maximal inhibitory concentration: 152000 nM
Beside the measured number, compound 4's estimate is 1.6-fold (0.22 log units) above it; measured number inside the range.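

In this assay, trifluoromethyl in place of ethyl on a sulfonyl sulfur gives a 1.6-fold higher number from compound 2 to compound 4 (0.21 log units; within the scatter), so on this core the change cannot be told apart from no change at all. The change therefore did not carry over at the same size from one core to the other: the same change on two cores in this assay, an at least 9.4-fold higher number (0.97 log units; beyond the scatter) from compound 1 to compound 3 and a 1.6-fold higher number (0.21 log units; within the scatter) from compound 2 to compound 4, at least 5.9-fold (0.77 log units) apart, beyond the scatter of two such steps. As far as these compounds go, the true size of the earlier step remains unknown, and the gap between the two steps is only a lower bound, since compound 3 gives a limit rather than a number: the limit of > 250000 nM in this assay, at which 1 of the 4 values shown sits.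

With only two cores shown, what in the cores sets the size of the step stays open. So does how a methyl group or a longer chain such as propyl on the sulfonyl sulfur would behave on either core.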